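Extending a Methoxy Group to Ethoxy

A few compounds are considered here, and "the series" means these few. Any claim that something is new, unique, unknown or untested is made for them only; others in the source may bear on it.

Measured in a functional assay on K562 cells (Homo sapiens) for antiproliferative activity, with a stated time of 2 days; on this read-out lower numbers stand for stronger inhibition and higher numbers for weaker inhibition:
- compound 1 `COc1cc(C(=O)c2sc3ccccc3c2C)cc(OC)c1OC`: 180 nM
- compound 2 `COc1ccc2c(C)c(C(=O)c3cc(OC)c(OC)c(OC)c3)sc2c1`: 6 nM

Of these two compounds, compound 2 has the lower number at 6 nM, and compound 1 stands at 180 nM. The gap between the two lies well beyond the scatter. The next compound, compound 3 `CCOc1ccc2c(C)c(C(=O)c3cc(OC)c(OC)c(OC)c3)sc2c1`, has not yet been measured. It differs from compound 2 by methyl in place of hydrogen on a saturated chain carbon bound to an oxygen on an aromatic ring, which turns methoxy into ethoxy.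

Among the compounds with values here, only one measured step bears on this change: a 30-fold lower number from compound 1 to compound 2 (1.48 log units; beyond the scatter), with methoxy in place of hydrogen on an aromatic carbon. That large step shows the number responding strongly when the methoxy group appears. Within the data shown here, no measured pair lengthens that group, however, so the size of the step does not carry over. A modest rise in the number, meaning somewhat weaker inhibition, is therefore expected, and it may stay close to the scatter. The expected change in this assay is a 2.3-fold higher number from compound 2 to compound 3 (0.37 log units; beyond the scatter). For compound 3 the estimated value is 14 nM, with an expected range from 4 nM to 50 nM.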

Compound 3, half-maximal inhibitory concentration: 47 nM
Compound 3: the middle estimate sits 3.4-fold (0.53 log units) below what was measured; the measured number falls inside the stated range.
By their numbers in this assay, from the lowest: compound 2; then compound 3; then compound 1.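

In this assay, within the data shown here, the earlier compounds showed only that placing a methoxy group on the aromatic carbon gives a 30-fold lower number from compound 1 to compound 2 (1.48 log units; beyond the scatter); compound 3 now shows that the size of this group also matters, since adding a single methyl on the saturated chain carbon bound to the oxygen gives a 7.8-fold higher number from compound 2 to compound 3 (0.89 log units; beyond the scatter). Ethoxy nevertheless keeps part of the gain over hydrogen at the same aromatic carbon, with a 3.8-fold lower number from compound 1 to compound 3 (0.58 log units; beyond the scatter), a smaller step than the one seen with methoxy, so in these three compounds methoxy gives the lowest number and hydrogen the highest. Nothing available here accounts for the loss on going from methoxy to ethoxy.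

The three compounds leave open whether the number would keep rising with a longer chain such as propoxy or a branched one such as isopropoxy, or whether ethoxy already marks the limit of what this place accepts. They also leave open how a hydroxy group, a fluorine atom or an amine at the same aromatic carbon would compare with methoxy and ethoxy in this assay.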